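Aryl substituent series in a pancreatic cell cytotoxicity screen

The source may hold more compounds than are shown below. What is called first, only, known or untested is meant among the compounds shown, and "the series" means these compounds.

Values in a functional assay on PANC-1 cells (Homo sapiens) for cytotoxicity, read by MTT assay, with a stated time of 72 h, tested at 10 uM; a higher number here means a weaker effect of the compound at the concentration tested, a lower number a stronger effect:
compound 1 `C=C1C(=O)O[C@H](c2ccccc2)[C@H]1c1ccccc1`: 1%
compound 2 `C=C1C(=O)O[C@H](c2ccc(OC)cc2)[C@H]1c1ccccc1`: 0%
compound 3 `C=C1C(=O)O[C@H](c2ccc(C)cc2)[C@H]1c1ccccc1`: 0%

Compound 3 stands level with compound 2 at the digits given, the two together the lowest of the three numbers; its separation from compound 1 is a number 1 percentage points lower from compound 1 to compound 3 (within the scatter). The other steps are a number 1 percentage points lower from compound 1 to compound 2 (within the scatter) and no change at the digits printed from compound 2 to compound 3 (within the scatter), so all three measured changes at this aromatic carbon fall within the scatter.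

Compound 4 `C=C1C(=O)O[C@H](c2ccc(C(F)(F)F)cc2)[C@H]1c1ccccc1` differs from compound 3 by trifluoromethyl in place of methyl on an aromatic carbon. Going by the values given here, no measured step introduces a trifluoromethyl, so the expectation rests on the flat behaviour of the three measured steps. Compound 4 is therefore expected to show a number 2 percentage points higher from compound 3 to compound 4 (within the scatter), no step beyond the scatter. The estimate for compound 4 is 2%, with a range from 0% to 12%.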

Compound 4, a percentage reported as activity, at one concentration (the size of the read-out at that concentration, not a potency): 33%
Estimate against measurement, compound 4: 31 percentage points below; the whole stated range lies below it.
By their numbers in this assay, from the lowest: compounds 2, 3 and 1 (each within the scatter of the next); then compound 4.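

In this assay, going by these compounds alone, trifluoromethyl is the first change at this aromatic carbon to go beyond the scatter: a number 33 percentage points higher from compound 3 to compound 4 (beyond the scatter), a number 33 percentage points higher from compound 2 to compound 4 (beyond the scatter) and a number 32 percentage points higher from compound 1 to compound 4 (beyond the scatter). The read-out at this carbon therefore does depend on the group placed there, which hydrogen, methyl and methoxy did not reveal. No available evidence bears on the origin of this step.

As far as these compounds go, whether trifluoromethyl stands alone remains open, and a chlorine, a nitrile or a carboxylic acid at this carbon would test that. Also open, from the compounds shown here alone, is whether trifluoromethyl elsewhere on the shared core gives a similar step.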